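Replacing the 1-(hydroxymethyl)cyclopropyl group of compound 3

The source may report more compounds than this note shows. Statements on the series, on what has been measured and on what is new or still open speak of the compounds shown alone.

Compound 1 `CCn1c(C(=O)NCCC(=O)OC)ccc1C(CC)(CC)c1ccc(OCS(=O)(=O)c2ccccc2)c(C)c1`: 40400 nM
Compound 2 `CCn1c(C(=O)NC(C)(C)CO)ccc1C(CC)(CC)c1ccc(OCS(=O)(=O)c2ccccc2)c(C)c1`: 9850 nM
Compound 3 `CCn1c(C(=O)NC2(CO)CC2)ccc1C(CC)(CC)c1ccc(OCS(=O)(=O)c2ccccc2)c(C)c1`: 3560 nM

These values come from a functional assay on PC-3 cells (Homo sapiens) for antiproliferative activity, read by MTT assay, with a stated time of 24 h; on this read-out higher numbers stand for weaker inhibition and lower numbers for stronger inhibition. Compound 3 has the lowest number of the three, and its nearest neighbour is compound 2. Compound 4 `CCn1c(C(=O)N[C@@H](CO)CCCO)ccc1C(CC)(CC)c1ccc(OCS(=O)(=O)c2ccccc2)c(C)c1` has not yet been measured. It keeps the shared core and differs from compound 3 only on the amide-type nitrogen: a group of 7 heavy atoms (5 carbon, 2 oxygen; no ring) in place of a group of 5 heavy atoms (4 carbon, 1 oxygen; one three-membered non-aromatic ring of carbon only), on an amide-type nitrogen.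

All three measured steps involve this same place. The changes there gave a 4.1-fold lower number from compound 1 to compound 2 (0.61 log units; beyond the scatter) and an 11-fold lower number from compound 1 to compound 3 (1.05 log units; beyond the scatter), so the group on this nitrogen can move the number substantially. The closest guide is a 2.8-fold lower number from compound 2 to compound 3 (0.44 log units; beyond the scatter), which is modest but beyond the scatter. Compound 2, whose group also has no ring, gives 9850 nM, so losing the ring of compound 3 is expected to bring a modest step to a higher number in this assay. Going by the values given here, no measured compound carries a group like the one entering, so this expectation remains uncertain, and the range is wide.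

The step expected is a 2.2-fold higher number from compound 3 to compound 4 (0.35 log units; beyond the scatter). For compound 4 the estimated value is 8000 nM, with an expected range from 2800 nM to 23000 nM.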

Compound 4, half-maximal inhibitory concentration: 13400 nM
Estimate against measurement, compound 4: 1.7-fold (0.22 log units) below; low and high end bracket the measured number.
By their numbers in this assay, from the lowest: compound 3; then compounds 2 and 4 (each within the scatter of the next); then compound 1.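

In this assay, the open-chain group of compound 4, with 2 hydrogen-bond donors, 2 hydrogen-bond acceptors and 1 defined stereocentre, does not match the 1-(hydroxymethyl)cyclopropyl group, with a 3.8-fold higher number from compound 3 to compound 4 (0.58 log units; beyond the scatter). Against the 1-(hydroxymethyl)-1-methylethyl group, which also has no ring, the result is a 1.4-fold higher number from compound 2 to compound 4 (0.13 log units; within the scatter), so compound 2 and compound 4 cannot be told apart here even though the entering group is larger. The same group still improves on the 2-(methoxycarbonyl)ethyl group, with a 3.0-fold lower number from compound 1 to compound 4 (0.48 log units; beyond the scatter), and among these four compounds the only group with a ring, that of compound 3, gives the lowest number, beyond the scatter of each open-chain group. Nothing available here accounts for these differences.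

The compounds shown leave open whether a ring of another size, as in 1-(hydroxymethyl)cyclobutyl, would keep the number of compound 3, or whether the cyclopropane ring is specific in this series. They also leave open what the mirror-image form of compound 4 would give, and how an amine or a carboxylic acid at the end of the chain would compare with its hydroxyl.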